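A few compounds are considered here, and "the series" means these few. Any claim that something is new, unique, unknown or untested is made for them only; others in the source may bear on it.

Compounds measured so far:
Compound 1, `CC(C)CCn1nc(-c2cccs2)c(O)c(C2=NS(=O)(=O)c3cc(OCC(N)=O)ccc3N2)c1=O`: 0.383 h
Compound 2, `NC(=O)COc1ccc2c(c1)S(=O)(=O)N=C(c1c(O)c(-c3cccs3)nn(CCC3CC3)c1=O)N2`: 0.2 h
Compound 3, `CC(C)(F)CCn1nc(-c2cccs2)c(O)c(C2=NS(=O)(=O)c3cc(OCC(N)=O)ccc3N2)c1=O`: 0.65 h

In an in vitro ADME assay on microsomes from liver (Homo sapiens) for metabolic stability (a higher number here means that the compound lasts longer, a lower number that the compound disappears faster), compound 3 is set apart from compound 2 by a 3.3-fold higher number from compound 2 to compound 3 (0.51 log units; beyond the scatter), a step beyond the scatter, whereas against compound 1 the step of a 1.7-fold higher number from compound 1 to compound 3 (0.23 log units; within the scatter) stays within the scatter. The next compound, compound 4 `CCC(C)(C)Cn1nc(-c2cccs2)c(O)c(C2=NS(=O)(=O)c3cc(OCC(N)=O)ccc3N2)c1=O`, differs from compound 3 in one place: 1,1-dimethylpropyl in place of 2-fluoro-2-methylpropyl on a saturated chain carbon bound to an aromatic nitrogen. Two of the measured steps bear on this. The fluoro-for-hydrogen step a 1.7-fold higher number from compound 1 to compound 3 (0.23 log units; within the scatter) was within the scatter, so removing the fluorine is not expected to move the number much on its own. The chain steps a 1.9-fold lower number from compound 1 to compound 2 (0.28 log units; within the scatter) and a 3.3-fold higher number from compound 2 to compound 3 (0.51 log units; beyond the scatter) show that reshaping the chain attached to the aromatic nitrogen has shifted the numbers by modest amounts at most. The expected change, a 1.4-fold lower number from compound 3 to compound 4 (0.16 log units; within the scatter), is estimated to fall within the scatter, leaning slightly downward. Compound 4 is therefore expected to give about 0.45 h, within a range from 0.22 h to 0.9 h.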

Compound 4, half-life: > 1 h
Compound 4 gave a limit, no number; the forecaster's own chance of this, stated with the estimate: 5%; at least 2.2-fold (0.34 log units) between middle value and limit.
By their numbers in this assay, from the lowest: compounds 2, 1 and 3 (each within the scatter of the next, the first and the last beyond it). At a limit, above all of these: compound 4.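

In this assay, compound 4 gives a limit and not a number: the limit of > 1 h in this assay, at which 1 of the 4 values shown sits.

Even so, the steps of an at least 5.0-fold higher number from compound 2 to compound 4 (0.69 log units; beyond the scatter) and an at least 2.6-fold higher number from compound 1 to compound 4 (0.41 log units; beyond the scatter) lie beyond the scatter, showing that an all-carbon 1,1-dimethylpropyl group on a saturated chain carbon bound to an aromatic nitrogen can give a longer half-life than the isobutyl and cyclopropylmethyl groups, with no fluorine present. The fluorinated comparison is less settled, since the floor of the step of an at least 1.5-fold higher number from compound 3 to compound 4 (0.18 log units; that floor lies within the scatter) lies within the scatter, so the change from 2-fluoro-2-methylpropyl to 1,1-dimethylpropyl may be small or large.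

As far as these compounds go, how far compound 4 lies beyond its limit remains open. So does whether a hydroxyl group or an ether oxygen on this chain, or a longer chain, would keep the half-life at this level.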